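This account rests on a few compounds, and the source may have more. Where it says the series, first, only, none or still open, it means among the compounds named here.

Measured compounds:
- compound 1, `Cn1c(-c2ccccc2)nc2c(NC3CCCCC3)ncnc21`: 5.7 nM
- compound 2, `CCCn1c(-c2ccccc2)nc2c(NC3CCOC3)ncnc21`: 25 nM
- compound 3, `CCCn1c(-c2ccccc2)nc2c(NC3CCCCC3)ncnc21`: 27 nM

In an assay on CHO cells for displacement of a labelled ligand from adenosine receptor A1 (Homo sapiens), read by scintillation counting, with a stated time of 3 h (a higher number here means a weaker inhibitor, a lower number a stronger inhibitor), compound 3 gives the highest number of the three, though compound 2 sits within the scatter of it (a 1.1-fold higher number from compound 2 to compound 3 (0.03 log units; within the scatter)), and compound 1 lies clearly lower (a 4.7-fold higher number from compound 1 to compound 3 (0.68 log units; beyond the scatter)).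

Compound 4, `CCCn1c(-c2ccccc2)nc2c(N)ncnc21`, differs from compound 3 in one place: hydrogen in place of cyclohexyl on a nitrogen on an aromatic ring. For the measured compounds named here, only the step from compound 2 to compound 3 touches this nitrogen, and there swapping one ring for another changed nothing beyond the scatter (a 1.1-fold higher number from compound 2 to compound 3 (0.03 log units; within the scatter)). No measured step removes the ring altogether; every measured compound carries a ring on that nitrogen, so the size of the loss is unconstrained by the data shown. The expectation for compound 4 is therefore a clearly higher number in this assay, with a wide range: a step of a 30-fold higher number from compound 3 to compound 4 (1.47 log units; beyond the scatter) is estimated. Compound 4 is estimated at 800 nM, somewhere between 100 nM and 6000 nM.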

Compound 4, inhibition constant: 101 nM
The estimate for compound 4 lay 7.9-fold (0.90 log units) above the measured number, and the stated range covers the measured number.
By their numbers in this assay, from the lowest: compound 1; then compounds 2 and 3 (each within the scatter of the next); then compound 4.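

In this assay, the substituent on this nitrogen proves to matter, which the ring-for-ring swap between compound 2 and compound 3 could not show: cyclohexylamino to amino gives (a 3.7-fold higher number from compound 3 to compound 4 (0.57 log units; beyond the scatter)), and loss of oxolan-3-yl gives (a 4.0-fold higher number from compound 2 to compound 4 (0.61 log units; beyond the scatter)). Both steps are modest and run the same way, so over these compounds a ring on the nitrogen goes with a lower number than the bare amino group, while cyclohexyl and oxolan-3-yl remain within the scatter of each other. Nothing at hand accounts for this difference.

On these data alone, whether a ring is needed at all stays open, since an open chain such as methyl or n-butyl, or an aromatic phenyl ring, on this nitrogen could place the number anywhere relative to these compounds. Also open, as far as these compounds go, is whether the step holds with methyl in place of propyl on the core, as in compound 1.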